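This account rests on a few compounds, and the source may have more. Where it says the series, first, only, none or still open, it means among the compounds named here.

Measured compounds:
Compound 1, `O=C(O)c1ccc(NCc2nc(-c3ccccc3)nn2-c2ccccc2)cc1`, gives -0.4% in an assay on Sf9 cells for inhibition of protein deacetylase HDAC6 (Homo sapiens), read by fluorescence, with a stated time of 40 min, tested at 100 nM; on this read-out higher numbers stand for more inhibition at the one concentration tested (going by the name of the read-out) and lower numbers for less inhibition.
Compound 2, `NNC(=O)c1ccc(NCc2nc(-c3ccccc3)nn2-c2ccccc2)cc1`, gives 10%.
Compound 3, `O=C(NO)c1ccc(NCc2nc(-c3ccc(C(F)(F)F)cc3)nn2-c2ccccc2)cc1`, gives 41.6%.

Among these three numbers compound 2 stands second highest. Its nearest neighbour is compound 1, which lies lower, and the step of a number 10.4 percentage points higher from compound 1 to compound 2 (beyond the scatter) is beyond the scatter though modest. Among the compounds with values here, compound 3, the only one of the three to carry a hydroxamic acid, stands far above compound 2; no single step joins them, since compound 3 also differs in the trifluoromethyl on one of the phenyl rings.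

The compound not yet measured is compound 4, `NC(=O)c1ccc(NCc2nc(-c3ccccc3)nn2-c2ccccc2)cc1`. It differs from compound 2 in one place: hydrogen in place of amino on an amide-type nitrogen. Within the data shown here, the only measured step that bears on this change is the one from compound 1 to compound 2, which swapped the group on the carbonyl carbon and moved the read-out by a number 10.4 percentage points higher from compound 1 to compound 2 (beyond the scatter). Compound 4 keeps the carbonyl and the amide-type nitrogen of compound 2 but sheds the amino on that nitrogen, and so sits structurally between compound 1 and compound 2. The expectation is therefore a small downward step, a number 6 percentage points lower from compound 2 to compound 4 (within the scatter), landing roughly midway between compound 1 and compound 2 and not clearly beyond the scatter. Compound 4 is estimated to give 4%, within the range -8% to 16%.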

Compound 4, a percentage reported as inhibition, at one concentration (the size of the read-out at that concentration, not a potency): -4.4%
Estimate against measurement, compound 4: 8.4 percentage points above, and the stated range covers the measured number.
By their numbers in this assay, from the lowest: compounds 4 and 1 (each within the scatter of the next); then compound 2; then compound 3.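

In this assay, taking the amino off the amide-type nitrogen gives a number 14.4 percentage points lower from compound 2 to compound 4 (beyond the scatter) and so removes the modest gain that the aminoamino group had shown over the hydroxy on the carbonyl carbon. Replacing that hydroxy with amino gives a number 4 percentage points lower from compound 1 to compound 4 (within the scatter) in the same assay, so the plain carbamoyl group cannot be told apart from the carboxylic acid, and on this carbonyl carbon only aminoamino stands clear of the other two groups, by a small margin. The data offer no measured explanation for why the second nitrogen makes this difference.

What the compounds shown leave open is whether that margin depends on the free amino itself or would also appear with a methylamino group or a longer chain, such as an ethylamino group, on the amide-type nitrogen. They also leave open how a hydroxy on that nitrogen would read on the unchanged core of compound 2, without the trifluoromethyl of compound 3, so the contribution of that hydroxy cannot be separated from the contribution of the trifluoromethyl.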